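A few compounds are considered here, and "the series" means these few. Any claim that something is new, unique, unknown or untested is made for them only; others in the source may bear on it.

Compound 2 `COc1cc(OC)c(OC)cc1/C=C/C(=O)c1ccc([N+](=O)[O-])cc1` stands at a limit of a functional assay on MCF7 cells (Homo sapiens) for inhibition, read by MTT assay, with a stated time of 72 h (a lower number here means a stronger inhibitor, a higher number a weaker inhibitor), rather than at a number, > 150000 nM. Compound 3 `COc1cc(OC)c(OC)cc1/C=C/C(=O)c1cccc([N+](=O)[O-])c1` likewise stops at a limit in this assay, > 150000 nM. Compound 1 `COc1cc(OC)c(OC)cc1/C=C/C(=O)c1ccc(C)cc1` gives 33000 nM in this assay. Among the measured compounds shown here, the one measured step, an at least 4.5-fold higher number from compound 1 to compound 2 (0.65 log units; beyond the scatter), is the only evidence that touches the same position, and it is bounded by the limit of > 150000 nM in this assay, at which 2 of the 3 values shown sit. Compound 4 `COc1cc(OC)c(OC)cc1/C=C/C(=O)c1ccc(Br)cc1` differs from compound 2 by bromo in place of nitro on an aromatic carbon. For the measured compounds named here, no measured step involves bromo, so the expectation rests on undoing the nitro step alone. Compound 4 is therefore expected to fall back toward a measurable number, a step of an at least 3.7-fold lower number from compound 2 to compound 4 (0.57 log units; beyond the scatter). For compound 4 the estimate is 40000 nM, with a range from 12000 nM to 150000 nM.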

Compound 4, half-maximal inhibitory concentration: 18300 nM
The estimate for compound 4 lay 2.2-fold (0.34 log units) above the measured number; the measured number falls inside the stated range.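

Putting bromo on this aromatic carbon gives an at least 8.1-fold lower number from compound 2 to compound 4 (0.91 log units; beyond the scatter) in this assay. Compound 2 stands at a limit of the assay and not at a number: the limit of > 150000 nM in this assay, at which 2 of the 4 values shown sit. Bromo and methyl cannot be told apart here, with a 1.8-fold lower number from compound 1 to compound 4 (0.26 log units; within the scatter), so among the groups shown at this place only nitro stands apart.

Going by these compounds, whether an amine or a carboxylic acid on this carbon would go with methyl and bromo or with nitro remains open. The compounds shown also do not tell what sets nitro apart.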